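3'-Sulfonate cytidines: exchanging (methylsulfonyl)oxy for fluoro

A few compounds are considered here, and "the series" means these few. Any claim that something is new, unique, unknown or untested is made for them only; others in the source may bear on it.

Measured so far:
compound 1, `Cc1ccc(S(=O)(=O)O[C@@H]2[C@@H](O)[C@H](n3ccc(N)nc3=O)O[C@@H]2CO)cc1`: 0.06 ug/mL
compound 2, `CS(=O)(=O)O[C@@H]1[C@@H](O)[C@H](n2cc(F)c(N)nc2=O)O[C@@H]1CO`: 0.02 ug/mL
compound 3, `CS(=O)(=O)O[C@@H]1[C@@H](O)[C@H](n2ccc(N)nc2=O)O[C@@H]1CO`: 0.03 ug/mL

In a functional assay on P815 cells (Mus musculus) for antiproliferative activity (on this read-out lower numbers stand for stronger inhibition and higher numbers for weaker inhibition), compound 3 stands second highest of the three numbers; its nearest neighbour is compound 2, a 1.5-fold higher number from compound 2 to compound 3 (0.18 log units; within the scatter) apart, its furthest compound 1, a 2.0-fold lower number from compound 1 to compound 3 (0.30 log units; within the scatter) apart. Both steps fall within the scatter, so the three numbers are not separated by this read-out.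

Compound 4, `Nc1ccn([C@@H]2O[C@H](CO)[C@H](F)[C@H]2O)c(=O)n1`, differs from compound 3 in one place: fluoro in place of (methylsulfonyl)oxy on a saturated ring carbon.

Neither measured step bears on this change. The step from compound 1 to compound 3 alters only the substituent on the sulfonyl sulfur, and the step from compound 2 to compound 3 alters only the aromatic ring; both leave the (methylsulfonyl)oxy group on the saturated ring carbon in place. For the measured compounds named here, no measured pair shows what happens when that group is replaced by fluoro, so no direction can be read from the series. The expectation for compound 4 therefore rests on nothing more than the spread of the three numbers, and a wide range is appropriate.

Compound 4 is estimated at 0.3 ug/mL in this assay, within a range of 0.03 ug/mL to 3 ug/mL. This estimate corresponds to an expected 10-fold higher number from compound 3 to compound 4 (1.00 log units; beyond the scatter), with the direction undetermined.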

Compound 4, concentration for 50% inhibition: 21 ug/mL
Beside the measured number, compound 4's estimate is 70-fold (1.85 log units) below it, and the stated range ends below it.
By their numbers in this assay, from the lowest: compounds 2, 3 and 1 (each within the scatter of the next, the first and the last beyond it); then compound 4.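

In this assay, the saturated ring carbon bearing the (methylsulfonyl)oxy group proves far more sensitive than either place varied earlier: fluoro in place of (methylsulfonyl)oxy gives a 700-fold higher number from compound 3 to compound 4 (2.85 log units; beyond the scatter), whereas the changes on the sulfonyl sulfur and on the aromatic carbon both stayed within the scatter. The tolerance seen on the sulfonyl sulfur, where methyl and 4-methylphenyl are not separated, therefore does not extend to replacing the whole group, and the low numbers of compounds 1, 2 and 3 all belong to compounds that keep a sulfonyl-bearing oxygen on this carbon. No supporting data are available to account for the size of this step.

The compounds shown leave open whether the large step reflects the loss of the sulfonate or the arrival of fluoro, and whether another group on this carbon, such as an amine, a methoxy group or an acetyl ester, would come close to compound 3 at 0.03 ug/mL. Also open, going by these compounds, is whether the ring fluoro of compound 2 would make any difference in a compound that carries fluoro on the saturated ring carbon.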